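Extending the amine chain on a cinnamanilide ether

This account rests on a few compounds, and the source may have more. Where it says the series, first, only, none or still open, it means among the compounds named here.

Compound 3 `COc1cc(/C=C/C(=O)Nc2ccccc2)ccc1OCCCCCN1CCCC1` gives 1.64 in a physicochemical assay for lipophilicity, using the shake flask method, measured as octanol-water partition, at pH 7.4 (a higher number here means a more lipophilic compound, a lower number a more polar compound), a number that lies second highest among the three measured and within the scatter of both neighbours. Compound 1 `COc1cc(/C=C/C(=O)Nc2ccccc2)ccc1OCCCCCN(C)C` gives 1.61 and compound 2 `COc1cc(/C=C/C(=O)Nc2ccccc2)ccc1OCCCCCN1CCCCC1` gives 1.65 in this assay. The steps of a number 0.04 log units higher from compound 1 to compound 2 (within the scatter), a number 0.03 log units higher from compound 1 to compound 3 (within the scatter) and a number 0.01 log units lower from compound 2 to compound 3 (within the scatter) show that exchanging one terminal amine for another at this position leaves the number unchanged.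

Compound 4 `COc1cc(/C=C/C(=O)Nc2ccccc2)ccc1OCCCCCCCCN(C)C` differs from compound 3 by 3-(dimethylamino)propyl in place of pyrrolidin-1-yl on a saturated chain carbon, five bonds along the chain from an oxygen on an aromatic ring. Going by the values given here, the measured steps bear only on the amine exchange part of this change, and all of them are flat; no measured step covers the longer chain that enters, so the expectation rests on the structural change alone. Since the entering group carries more heavy atoms and no ring, the step of a number 0.96 log units higher from compound 3 to compound 4 (beyond the scatter) is estimated to be higher. Compound 4 is therefore expected to give 2.6 in this assay, with a range from 1.9 to 3.4.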

Compound 4, partition coefficient: 1.74
Compound 4: middle estimate off by 0.86 log units, on the high side; measured number below the stated range.
By their numbers in this assay, from the lowest: compounds 1, 3, 2 and 4 (each within the scatter of the next).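

In this assay the step of a number 0.10 log units higher from compound 3 to compound 4 (within the scatter) and the step of a number 0.09 log units higher from compound 2 to compound 4 (within the scatter) show that 3-(dimethylamino)propyl can replace either ring amine at this position without a shift beyond the scatter. Going by these compounds alone, compound 1 and compound 4 both end in dimethylamino, so the step of a number 0.13 log units higher from compound 1 to compound 4 (within the scatter) isolates the longer chain, which no earlier step covered, and shows it to be as flat here as the exchange of terminal amines. No measured evidence is available that would account for this flatness.

The compounds shown leave open whether a terminal morpholin-4-yl group or a carboxylic acid in place of the amine would move the number at this position. They also leave open whether a still longer chain, or a shorter one, would stay equally flat.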